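The source may report more compounds than this note shows. Statements on the series, on what has been measured and on what is new or still open speak of the compounds shown alone.

Measured compounds:
- compound 1, `CCCOC(=O)c1c(C)coc1-c1ccc2c(CC)cccc2c1OC`: in a functional assay on KBVIN cells (Homo sapiens) for cytotoxicity, read by MTT assay, with a stated time of 72 h (on this read-out higher numbers stand for an effect only at larger amounts of compound and lower numbers for an effect already at smaller amounts), compound 1 gives > 10 ug/mL, which is a limit of the assay and not a number.
- compound 2, `CCc1cccc2c(OC)c(-c3occ(C)c3CO)ccc12`: in this assay compound 2 gives 6.6 ug/mL.
- compound 3, `CCOc1c(-c2occ(C)c2CO)ccc2c(CC)cccc12`: in this assay compound 3 gives 6.4 ug/mL.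

Among the two numbers shown, compound 2 stands highest, though its nearest neighbour compound 3 lies within the scatter of it, so the two cannot be told apart. Compound 1 sits at the limit of > 10 ug/mL in this assay, at which 1 of the 3 values shown sits.

The unmeasured compound 4 is `CCc1cccc2c(OC)c(-c3occ(C)c3COCC(F)(F)F)ccc12`. It differs from compound 2 by 2,2,2-trifluoroethyl in place of hydrogen on an oxygen on a saturated carbon. Among the compounds with values here, two measured steps touch this region. The step of an at least 1.5-fold lower number from compound 1 to compound 2 (0.18 log units; that floor lies within the scatter) exchanges the whole group on that aromatic carbon, and its floor lies within the scatter. The step of a 1.0-fold lower number from compound 2 to compound 3 (0.01 log units; within the scatter) extends a chain on an oxygen by one carbon and moves nothing beyond the scatter. Neither step is the same as capping the hydroxymethyl oxygen with a trifluoroethyl group, so only a loose guide is at hand, and no step beyond the scatter is expected.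

Compound 4 is therefore estimated to give 7 ug/mL, with a range from 3 ug/mL to 16 ug/mL. This estimate means an expected step of a 1.1-fold higher number from compound 2 to compound 4 (0.03 log units; within the scatter) in this assay.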

Compound 4, concentration for half-maximal effect: 6 ug/mL
Beside the measured number, compound 4's estimate is 1.2-fold (0.07 log units) above it, within the range that was stated.
By their numbers in this assay, from the lowest: compounds 4, 3 and 2 (each within the scatter of the next). At a limit, above all of these: compound 1.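

The earlier steps shown here left the oxygen of the hydroxymethyl group untouched; in this assay, placing 2,2,2-trifluoroethyl on it, a group of 5 heavy atoms, gives a 1.1-fold lower number from compound 2 to compound 4 (0.04 log units; within the scatter), so this position accepts that added bulk with no change that can be told from the scatter. Set against the propoxycarbonyl group on the aromatic carbon, the (2,2,2-trifluoroethoxy)methyl group gives an at least 1.6-fold lower number from compound 1 to compound 4 (0.22 log units; that floor lies within the scatter), which shows no step beyond the scatter. Compound 1 stands at a limit of the assay and not at a number, so that step is only a floor: the limit of > 10 ug/mL in this assay, at which 1 of the 4 values shown sits.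

Going by these compounds, whether an amine or a carboxylic acid in place of the hydroxy would leave the number just as unmoved remains open. So does the effect of a longer chain on this oxygen.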